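This account rests on a few compounds, and the source may have more. Where it says the series, first, only, none or still open, it means among the compounds named here.

Compound 1 `O=[N+]([O-])c1ccc(COc2cccc(Nc3ncnc4cc5c(cc34)OCCOCCO5)c2)cc1` — 15500 nM
Compound 2 `c1ccc(COc2cccc(Nc3ncnc4cc5c(cc34)OCCOCCO5)c2)cc1` — 7590 nM
Compound 3 `c1ccc(COc2cccc(Nc3ncnc4cc5c(cc34)OCCOCCOCCO5)c2)cc1` — > 100000 nM

The three compounds above share a core and were compared in a functional assay on A549 cells (Homo sapiens) for antiproliferative activity, read by MTT assay, with a stated time of 72 h; on this read-out higher numbers stand for weaker inhibition and lower numbers for stronger inhibition. Compound 2 gives 7590 nM in this assay. Compound 1 differs from it by nitro in place of hydrogen on an aromatic carbon, and this change produced a 2.0-fold higher number from compound 2 to compound 1 (0.31 log units; beyond the scatter).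

For compound 3 the assay gives only a limit, > 100000 nM, which is the limit of > 100000 nM in this assay, at which 1 of the 3 values shown sits. How the core of compound 3 differs from the core of compound 2 is not broken down here; the two differ in more than one place, and the difference is simply noted.

Compound 4 `O=[N+]([O-])c1ccc(COc2cccc(Nc3ncnc4cc5c(cc34)OCCOCCOCCO5)c2)cc1` has not yet been measured in this assay. It differs from compound 3 by nitro in place of hydrogen on an aromatic carbon, the same change that separates compound 1 from compound 2, placed on the same kind of aromatic carbon in the same position relative to the large group.

The expectation for compound 4 rests on two things. The earlier step, a 2.0-fold higher number from compound 2 to compound 1 (0.31 log units; beyond the scatter), went toward a higher number. The starting point already sits at the limit of the assay. Compound 4 is therefore expected to give about 180000 nM in this assay, most likely somewhere between 80000 nM and 500000 nM. The expected step is a step that the limit leaves unreadable from compound 3 to compound 4, and in practice the assay is expected to report only a limit again for compound 4.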

Compound 4, half-maximal inhibitory concentration: > 100000 nM
Compound 4 gave a limit, no number (the forecaster's own chance of this, stated with the estimate: 85%); the middle value is on the limit's open side.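

In this assay compound 4 gives > 100000 nM, which is a limit and not a number. Compound 3 also stands at a limit, so no step can be read between compound 3 and compound 4: the limit of > 100000 nM in this assay, at which 2 of the 4 values shown sit.

The compounds shown leave open whether nitro in place of hydrogen on an aromatic carbon changes the number at all on the core of compound 3, and in which direction.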